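The source may report more compounds than this note shows. Statements on the series, on what has been measured and on what is new or still open speak of the compounds shown alone.

Measured in an ADME assay on MRC5 cells (Homo sapiens) for cytotoxicity, read by fluorescence, with a stated time of 72 h; on this read-out lower numbers stand for stronger inhibition and higher numbers for weaker inhibition:

Compound 1 `CC1(COc2ccc(OC(F)(F)F)cc2)Cn2cc([N+](=O)[O-])nc2O1`: > 64000 nM
Compound 2 `CC1(COCc2ccc(OC(F)(F)F)cc2)Cn2cc([N+](=O)[O-])nc2O1`: 60000 nM

Compound 1 reads > 64000 nM and this is a limit of this assay and not a number. Compound 3 `CC1(COc2ccc(Oc3ccccc3)cc2)Cn2cc([N+](=O)[O-])nc2O1` keeps the core of compound 1 but carries phenyl in place of trifluoromethyl on an oxygen on an aromatic ring, which, cut one bond further out, reads trifluoromethoxy to phenoxy. No measured step sizes this change in this assay. Within the data shown here, the only true number so far is that of compound 2 at 60000 nM, so weak inhibition is expected to persist. The estimated move, an at least 1.4-fold lower number from compound 1 to compound 3 (0.15 log units; that floor lies within the scatter), is expected to be modest and towards stronger inhibition, and it may not clear the usual scatter. Compound 3 is expected to read about 45000 nM. The estimated range runs from 20000 nM to 64000 nM.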

Compound 3, half-maximal inhibitory concentration: > 64000 nM
Compound 3: a limit, no number; the forecaster's own chance of this, stated with the estimate: 45%; middle value at least 1.4-fold (0.15 log units) from the limit.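

In this assay compound 3 gives > 64000 nM, which is a limit and not a number. Among these compounds, compound 1 also reads as a limit, so no step between compound 1 and compound 3 can be read: the limit of > 64000 nM in this assay, at which 2 of the 3 values shown sit. Going by these compounds, whether trifluoromethoxy to phenoxy changes the read-out at all remains open.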